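Chloro to Isopropyl: An Expected Step in Rat

The source may hold more compounds than are shown below. What is called first, only, known or untested is meant among the compounds shown, and "the series" means these compounds.

Measured compounds:
compound 1, `CCCCc1ccc(-c2cc(Cl)cc(C(=O)Nc3nn[nH]n3)n2)cc1`, 0%
compound 2, `COc1cc(C(=O)Nc2nn[nH]n2)nc(-c2ccc(Cl)cc2)c1`, 0%

Both compounds were tested in a functional assay on the whole organism with Rattus norvegicus as the target, at a dose of 1 mg/kg by the oral route; a higher number here means a stronger effect of the compound at the dose given, a lower number a weaker effect. Compound 1 gives 0%, and compound 2 gives 0%. Compound 2 thus stands level with compound 1 at the digits recorded; the two values lie within the usual scatter of this kind of measurement, so nothing separates them. Neither compound shows an effect at this dose.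

Compound 3, `COc1cc(C(=O)Nc2nn[nH]n2)nc(-c2ccc(C(C)C)cc2)c1`, has not yet been measured. It differs from compound 2 in one place:

isopropyl in place of chloro on an aromatic carbon

Among the compounds with values here, no pair of measured compounds differs in a single place, so there is no measured step to lean on. Given that compound 2 gives 0% and compound 1 gives 0%, the expected step is a number 2 percentage points higher from compound 2 to compound 3 (within the scatter), none beyond the scatter. Compound 3 is therefore expected to give 2% in this assay, within a range from 0% to 15%.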

Compound 3, a percentage reported as inhibition, in the whole organism at one dose (the size of the read-out at that dose, not a potency): 54%
Compound 3: middle estimate off by 52 percentage points, on the low side, and the stated range ends below it.
By their numbers in this assay, from the lowest: compounds 1 and 2 (each within the scatter of the next); then compound 3.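

Isopropyl in place of chloro, on an aromatic carbon para to a large group, brings a number 54 percentage points higher from compound 2 to compound 3 (beyond the scatter) in this assay. Within the data shown here, compounds 1 and 2 sat level and offered no single-place step, so they could not show that this position matters; this one change turns a compound without an effect at this dose into one with a clear effect. No measurement accompanies the result that could account for the gain, so its reason stays unknown.

As far as these compounds go, it remains open whether other groups at this position, such as methyl, tert-butyl or methoxy, would give a similar result or whether the effect is specific to isopropyl. Also open, from the compounds shown here alone, is how compound 3 behaves at other doses, since a single dose shows the size of an effect and not a potency.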